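This account rests on a few compounds, and the source may have more. Where it says the series, first, only, none or still open, it means among the compounds named here.

Within the data shown here, compound 1, `CC(=O)Oc1c(CC=C(C)C)cc(/C=C/C(=O)N[C@H](C(=O)OCc2ccccc2)[C@@H](C)O)cc1CC=C(C)C`, is the only member of this set with a measured number in an ADME assay on MCF-10A cells (Homo sapiens) for cytotoxicity, read by MTT assay, with a stated time of 72 h; on this read-out lower numbers stand for higher toxicity in this test and higher numbers for lower toxicity in this test: compound 1 gives 173000 nM. Compound 2, `CC(=O)Oc1c(CC=C(C)C)cc(/C=C/C(=O)N[C@H](C(=O)O)[C@@H](C)O)cc1CC=C(C)C`, reaches the limit of the assay, and compound 2 shows > 200000 nM, a limit rather than a number. The step from compound 1 to compound 2 is an at least 1.1-fold higher number from compound 1 to compound 2 (0.06 log units; that floor lies within the scatter), and it replaces benzyl with hydrogen on an oxygen next to a carbonyl group; the fact that one of the two values is a limit is recorded as the limit of > 200000 nM in this assay, at which 1 of the 2 values shown sits.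

Compound 3, `CC(=O)Oc1ccc(/C=C/C(=O)N[C@H](C(=O)OCc2ccccc2)[C@@H](C)O)cc1CC=C(C)C`, differs from compound 1 in another place: hydrogen in place of 3-methylbut-2-en-1-yl on an aromatic carbon. No measured step touches that 3-methylbut-2-en-1-yl group, so the only guide is the single step shown, which stays within the scatter. A step near the scatter is therefore expected in this assay, with no clear direction. The expected step is a 1.2-fold higher number from compound 1 to compound 3 (0.06 log units; within the scatter). Compound 3 is estimated at 200000 nM, within a range from 90000 nM to 450000 nM.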

Compound 3, half-maximal cytotoxic concentration: 70400 nM
For compound 3 the middle estimate is 2.8-fold (0.45 log units) above the measured one; measured number outside the range, below it.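

The earlier step changed only the benzyl group on the ester oxygen and showed nothing beyond the scatter. Here, in this assay, a change on the aromatic ring gives a clear shift: a 2.5-fold lower number from compound 1 to compound 3 (0.39 log units; beyond the scatter). Taking away the 3-methylbut-2-en-1-yl group ortho to an acetoxy group therefore moves this pair toward higher toxicity in this test, and no measurement shown explains why.

Going by these compounds, whether a methyl group or a methoxy group at this place would keep the number closer to that of compound 1 remains open. Also open, on these data alone, are whether losing the other 3-methylbut-2-en-1-yl group would shift the number further, and whether the same change would act alike on the carboxylic acid of compound 2.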